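A few compounds are considered here, and "the series" means these few. Any claim that something is new, unique, unknown or untested is made for them only; others in the source may bear on it.

Compound 1 (`CC(C)=CCC/C(C)=C/CC/C(C)=C/COc1cc2ccccc2oc1=O`) and compound 2 (`CC(C)=CCC/C(C)=C/CC/C(C)=C/COc1ccccc1`) were both tested in an assay on isolated protein for inhibition of Polyunsaturated fatty acid lipoxygenase ALOX15 (Homo sapiens); a higher number here means a weaker inhibitor, a lower number a stronger inhibitor. For compound 1 the result is only a limit of the assay, > 50000 nM. For compound 2 the result is likewise a limit, > 50000 nM. Compound 1 therefore stands at the limit of > 50000 nM in this assay, at which 2 of the 2 values shown sit, with nothing to rank it against. Compound 3 (`CC(C)=CCC/C(C)=C/COc1cc2ccccc2oc1=O`) keeps the core of compound 1 and differs by hydrogen in place of 3-methylbut-2-en-1-yl on a saturated chain carbon bound to a double-bonded chain carbon. Among the measured compounds shown here, no measured pair shows this change, so the step that the limit leaves unreadable from compound 1 to compound 3 is expected to be none beyond the scatter. Compound 3 is estimated at 60000 nM, between 20000 nM and 200000 nM.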

Compound 3, half-maximal inhibitory concentration: > 100000 nM
Compound 3: only a limit was reported; the forecaster's own chance of this, stated with the estimate: 75%; middle value at least 1.6-fold (0.22 log units) away from the limit.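

No step can be read from compound 1 to compound 3: in this assay both results are limits, not numbers. The compounds shown leave open how strongly any of them inhibits, and whether losing 3-methylbut-2-en-1-yl changes that.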